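A few compounds are considered here, and "the series" means these few. Any claim that something is new, unique, unknown or untested is made for them only; others in the source may bear on it.

Three compounds carry numbers in a functional assay on the whole organism for inhibition, with Mus musculus as the target, at a dose of 10 mg/kg by the oral route; a higher number here means more inhibition at the dose given (going by the name of the read-out), a lower number less inhibition. Compound 1 `CSc1ccc2c(c1)c(O)c(C(=O)N(C)c1ccccc1)c(=O)n2C` gives 67%; compound 2 `CSc1ccc2c(c1)c(O)c(C(=S)N(C)c1ccccc1)c(=O)n2C` gives 32%; compound 3 `CN1C(=O)/C(=C(/S)N(C)c2ccc(OC(F)(F)F)cc2)C(=O)c2cc(Cl)ccc21` gives 39%. Compound 3 thus holds the second highest of the three numbers: its nearest neighbour is compound 2, a gap within the scatter, and its furthest is compound 1, a gap beyond it. Compound 4 `CN1C(=O)/C(=C(/S)N(C)c2ccc(Br)cc2)C(=O)c2cc(Cl)ccc21` is the next to be measured in this assay. It differs from compound 3 in one place: bromo in place of trifluoromethoxy on an aromatic carbon. Going by the values given here, no measured pair shows a change of this kind, so no step beyond the scatter is expected here. The estimated step of a number 1 percentage points higher from compound 3 to compound 4 (within the scatter) is accordingly small. Compound 4 is expected to give about 40%, between 15% and 65%.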

Compound 4, a percentage reported as inhibition, in the whole organism at one dose (the size of the read-out at that dose, not a potency): 50%
Beside the measured number, compound 4's estimate is 10 percentage points below it, within the range that was stated.
By their numbers in this assay, from the lowest: compounds 2 and 3 (each within the scatter of the next); then compound 4; then compound 1.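

In this assay, going by these compounds alone, bromo in place of trifluoromethoxy gives a number 11 percentage points higher from compound 3 to compound 4 (beyond the scatter) on this aromatic carbon, para to a large group, the first one-place step. The read-out therefore responds to the group at this position, and the single heavy atom of bromo gives more inhibition here than the 5 heavy atoms of trifluoromethoxy. Nothing measured accounts for the step.

One step sets no trend. On these data alone, how a nitrile, a methoxy or an amine would read at this carbon remains open.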